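Methoxy in Place of Methylsulfanyl: A Small Expected Shift

A few compounds are considered here, and "the series" means these few. Any claim that something is new, unique, unknown or untested is made for them only; others in the source may bear on it.

Compound 1 `CSc1ccc(CNc2nc(SC)nc3ncccc23)cc1` was tested in a functional assay on CCRF-CEM cells (Homo sapiens) for cytotoxicity, read by MTT assay, with a stated time of 72 h (a higher number here means a weaker inhibitor of growth, a lower number a stronger inhibitor of growth), where compound 1 gives 5350 nM. Among the three compounds measured, this is the lowest number, meaning the strongest inhibition of growth. Compound 2 `CCCCC[Se]c1nc(NCc2ccc(SC)cc2)c2ccccc2n1` gives 35000 nM in this assay, and compound 3 `CSc1nc(NCCCc2ccccc2)c2ccccc2n1` gives 39500 nM; both differ from compound 1 by more than the usual scatter, so compound 1 stands clearly apart as the most potent of the three. Going by the values given here, no pair of these measured compounds differs in only one place, so no single structural step can be read from them.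

Compound 4 `COc1ccc(CNc2nc(SC)nc3ncccc23)cc1` has not yet been measured. It differs from compound 1 by one change: methoxy in place of methylsulfanyl on an aromatic carbon. Among the compounds with values here, nothing among the measured compounds shows what such a swap does here. The step of a 1.4-fold higher number from compound 1 to compound 4 (0.15 log units; within the scatter) is expected to be small, pointing toward a somewhat higher number, yet not clearly beyond the scatter. Compound 4 is therefore estimated at 7500 nM in this assay, with a likely range from 2500 nM to 22000 nM.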

Compound 4, concentration for 50% growth inhibition: > 100000 nM
Compound 4: a limit, no number; the forecaster's own chance of this, stated with the estimate: 5%; middle value at least 13-fold (1.12 log units) away from the limit.
By their numbers in this assay, from the lowest: compound 1; then compounds 2 and 3 (each within the scatter of the next). At a limit, above all of these: compound 4.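

In this assay, exchanging methylsulfanyl for methoxy at this aromatic carbon is far from a neutral swap: the change gives an at least 18-fold higher number from compound 1 to compound 4 (1.27 log units; beyond the scatter), although the two groups match in heavy-atom count and hydrogen-bond acceptors. Going by these compounds alone, compound 4 gives > 100000 nM, which is a limit of the assay and not a number, so the full size of the step stays unknown: the limit of > 100000 nM in this assay, at which 1 of the 4 values shown sits. The earlier compounds included no pair differing in one place, whereas this pair shows that growth inhibition by compound 1 depends strongly on the group at this position, para to a large group.

Why replacing one sulfur with one oxygen has so large an effect cannot be told from these compounds. From the compounds shown here alone, it also remains open whether a chlorine, an amine or a longer chain such as ethylsulfanyl at this position would retain the activity of compound 1.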